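The source may hold more compounds than are shown below. What is called first, only, known or untested is meant among the compounds shown, and "the series" means these compounds.

Measured so far:
- compound 1, `Cc1cccc(NC(=O)CN2CCN(c3cccc4ccccc34)CC2)c1`: 27.8%
- compound 2, `Cc1ccc(C2CCN(CC(=O)Nc3cccc(C)c3)CC2)nc1`: "not active" (no number reported), with no number
- compound 3, `Cc1cccc(NC(=O)CCN2CCC(c3ccccn3)CC2)c1`: 28.1%

In a functional assay on cells for agonist activity at D(4) dopamine receptor (Homo sapiens), read by TR-FRET and cAMP accumulation, with a stated time of 30 min (a lower number here means a smaller maximal response, a higher number a larger maximal response), compound 1 reaches 27.8%, and compound 3 reaches 28.1%; the two values lie within the usual scatter of each other, so nothing separates them. Compound 2 stands apart from these two: in this assay compound 2 was reported as "not active" (no number reported), and no single number was given for it. Among the measured compounds shown here, that leaves compound 2 without a fixed point on the scale, and no step can be measured from it to any other compound.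

Compound 4, `Cc1cccc(NC(=O)CN2CCC(c3ccc(Cl)cc3)CC2)c1`, differs from compound 2 in one place: 4-chlorophenyl in place of 5-methylpyridin-2-yl on a saturated ring carbon. For the measured compounds named here, no measured pair shows what such a change does in this assay, so the size of the step cannot be taken from the data. What remains is the company compound 4 keeps: it shares its amide part with compound 1 and compound 3, both of which give a modest maximal response. Compound 2 is reported as "not active" (no number reported), and a step upward from that to a low but measurable response is therefore expected for compound 4, though the chance that it too is reported as not active remains real. For compound 4 the maximal response in this assay is estimated at 25%, with a range from 5% to 45%.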

Compound 4, largest response reached (Emax), in percent of the reference or control that the assay uses: "not active" (no number reported)
Nothing numeric was reported for compound 4; the estimate stays without a comparison.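

In this assay compound 2 and compound 4 are both reported as not active, with no number, so no step can be read between them. No measurement shown accounts for this result. The compounds shown leave open whether 4-chlorophenyl and 5-methylpyridin-2-yl differ in their effect on the maximal response.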